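The source may hold more compounds than are shown below. What is called first, only, known or untested is meant among the compounds shown, and "the series" means these compounds.

Compound 1 `CN(C)Cc1ccncc1-c1ccc(-c2ccc3c(C(N)=O)nn(-c4ccc5onc(N)c5c4)c3c2F)c(F)c1`: in an assay on isolated protein for inhibition of Trypsin (Homo sapiens) (on this read-out higher numbers stand for weaker inhibition and lower numbers for stronger inhibition), compound 1 gives > 10000 nM, which is a limit of the assay and not a number.
Compound 2 `CN(C)Cc1cnccc1-c1ccc(-c2ccc3c(C(N)=O)nn(-c4ccc5onc(N)c5c4)c3c2F)c(F)c1`: in this assay compound 2 gives > 10000 nM, likewise a limit.

Among the measured compounds shown here, compound 2 therefore stands only at a limit in this assay, and the single measured step, a step that the two limits leave unreadable from compound 1 to compound 2, cannot be read. Compound 3 `CN(C)Cc1ncccc1-c1ccc(-c2ccc3c(C(N)=O)nn(-c4ccc5onc(N)c5c4)c3c2F)c(F)c1` differs from compound 2 by 2-((dimethylamino)methyl)pyridin-3-yl in place of 3-((dimethylamino)methyl)pyridin-4-yl on an aromatic carbon. For the measured compounds named here, no measured step speaks to the size or direction of this change; all that is known is the limit of > 10000 nM in this assay, at which 2 of the 2 values shown sit. The expected step is thus a step that the limit leaves unreadable from compound 2 to compound 3, nothing beyond the scatter. Compound 3 is estimated at 20000 nM, in a range from 5000 nM to 80000 nM, and most likely again reported only as a limit.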

Compound 3, inhibition constant: > 10000 nM
Compound 3: a limit, no number; the forecaster's own chance of this, stated with the estimate: 85%; the middle value is on the limit's open side.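

Among the compounds shown here, no step among compound 1, compound 2 and compound 3 can be read, since each value is only a limit of the assay: the limit of > 10000 nM in this assay, at which 3 of the 3 values shown sit. On these data alone, whether the three compounds truly differ at all in this assay stays open.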